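The source may report more compounds than this note shows. Statements on the series, on what has been measured and on what is new or still open speak of the compounds shown alone.

Measured compounds: compound 1 `COc1ccc(-c2cc(/C=C/C(=O)c3ccc(N)cc3)[nH]n2)cc1` at 76% in a functional assay on SN12C cells (Homo sapiens) for cytotoxicity, read by sulforhodamine B assay, with a stated time of 48 h, tested at 1 uM; a lower number here means a stronger effect, a higher number a weaker effect of the compound at the concentration tested; compound 2 `COc1ccc(-c2cc(/C=C/C(=O)c3ccc(N)cc3)[nH]n2)cc1OC` at 93% in this assay; compound 3 `COc1cc(C(=O)/C=C/c2cc(-c3cc(OC)c(OC)c(OC)c3)n[nH]2)cc(OC)c1OC` at 78% in this assay.

Between compound 2 and compound 1 the change is hydrogen in place of methoxy on an aromatic carbon; it produced a number 17 percentage points lower from compound 2 to compound 1 (beyond the scatter). Compound 4 `COc1ccc(-c2cc(/C=C/C(=O)c3cc(OC)c(OC)c(OC)c3)[nH]n2)cc1OC` differs from compound 3 by hydrogen in place of methoxy on an aromatic carbon. This is the same kind of change, not the same: in compound 3 the place is also meta to a methoxy group, which the place in compound 2 lacks. The difference between the cores of compound 2 and compound 3 is not broken down here; compound 3 stands close to compound 1, within the scatter, and beyond the scatter from compound 2.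

The expected step is a number 16 percentage points lower from compound 3 to compound 4 (beyond the scatter), because a number 17 percentage points lower from compound 2 to compound 1 (beyond the scatter) followed the same kind of change. Compound 4 is therefore expected to give 62%, estimated between 46% and 80%.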

Compound 4, a percentage reported as activity, at one concentration (the size of the read-out at that concentration, not a potency): 87%
Compound 4: the middle estimate sits 25 percentage points below what was measured; the whole stated range lies below it.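

In this assay the replacement of methoxy by hydrogen on an aromatic carbon gave a number 9 percentage points higher from compound 3 to compound 4 (within the scatter) and so did not repeat the earlier step, and the two steps differ: the same change on two cores in this assay, a number 17 percentage points lower (beyond the scatter) from compound 2 to compound 1 and a number 9 percentage points higher (within the scatter) from compound 3 to compound 4, 26 percentage points apart, beyond the scatter of two such steps. The size of that step therefore cannot be carried from the core of compound 2 to the core of compound 3 in this series. This does not show what separates the two cores, since the place of the change also differs between the pairs, and two pairs say nothing about any other core.

The compounds shown leave open whether a hydroxy group or a chlorine atom in that place would follow the same course on both cores.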